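Aryl substituent change on the shared core

This account rests on a few compounds, and the source may have more. Where it says the series, first, only, none or still open, it means among the compounds named here.

compound 1 `CCCS(=O)(=O)Nc1ccc(F)c(C(=O)c2n[nH]c3ncc(-c4cccc(C)c4)cc23)c1F` — 15%
compound 2 `CCCS(=O)(=O)Nc1ccc(F)c(C(=O)c2n[nH]c3ncc(-c4ccc(C)cc4)cc23)c1F` — 5.4%

In an assay for binding affinity to dual specificity mitogen-activated protein kinase kinase 4 (Homo sapiens), read by KINOMEscan, tested at 100 nM (a lower number here means a stronger effect, a higher number a weaker effect of the compound at the concentration tested), compound 2 gives 5.4%, and compound 1 gives 15%; the two sit within the scatter of each other, as the step of a number 9.6 percentage points lower from compound 1 to compound 2 (within the scatter) shows. Compound 3 `CCCS(=O)(=O)Nc1ccc(F)c(C(=O)c2n[nH]c3ncc(-c4ccccc4OC)cc23)c1F` differs from compound 2 by 2-methoxyphenyl in place of 4-methylphenyl on an aromatic carbon. Among the measured compounds shown here, the one measured step, a number 9.6 percentage points lower from compound 1 to compound 2 (within the scatter), bears on it only loosely, since no measured compound carries a methoxy group. On that basis the step from compound 2 to compound 3 is expected to stay within the scatter, a number 9.6 percentage points higher from compound 2 to compound 3 (within the scatter). Compound 3 is therefore estimated at 15%, in the range 3% to 45%.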

Compound 3, a percentage reported as activity, at one concentration (the size of the read-out at that concentration, not a potency): 1.9%
Beside the measured number, compound 3's estimate is 13.1 percentage points above it, outside the stated range (below it).
By their numbers in this assay, from the lowest: compounds 3, 2 and 1 (each within the scatter of the next, the first and the last beyond it).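

In this assay, this aromatic carbon accepts 2-methoxyphenyl, which brings a hydrogen-bond acceptor absent from the methylphenyl groups, with a number 3.5 percentage points lower from compound 2 to compound 3 (within the scatter). Set against 3-methylphenyl, the same group gives a number 13.1 percentage points lower from compound 1 to compound 3 (beyond the scatter), the first step in the series beyond the scatter. Nothing available explains this difference.

Still open, from the compounds shown here alone, is whether the methoxy group itself or its place on the phenyl ring accounts for that step, as the two change together. Going by these compounds, how an amine or a carboxylic acid on that phenyl ring would read in this assay also remains unknown.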